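Methyl to Methoxy on Two Different Cores

A few compounds are considered here, and "the series" means these few. Any claim that something is new, unique, unknown or untested is made for them only; others in the source may bear on it.

Compound 1 `COc1cccc(N2C(=O)CS/C2=N\c2csc(-c3ccc(C)cc3)c2)c1` and compound 2 `COc1ccc(-c2cc(/N=C3\SCC(=O)N3c3cccc(OC)c3)cs2)cc1` share one core and differ by methoxy in place of methyl on an aromatic carbon. In a functional assay on HT-29 cells (Homo sapiens) for cytotoxicity, read by MTT assay, with a stated time of 72 h (on this read-out lower numbers stand for stronger inhibition and higher numbers for weaker inhibition), compound 1 gives only a limit, > 50000 nM, which is the limit of > 50000 nM in this assay, at which 1 of the 3 values shown sits. In this assay compound 2 gives 11700 nM. The step of an at least 4.2-fold lower number from compound 1 to compound 2 (0.63 log units; beyond the scatter) is thus measured against a limit at one end. Compound 3 `Cc1ccc(/C=C2\S/C(=N\c3nc(-c4ccc(Cl)cc4)cs3)NC2=O)cc1` is built on another core; the difference between the two cores is not broken down here. In this assay compound 3 gives 500 nM. Compound 4 `COc1ccc(/C=C2\S/C(=N\c3nc(-c4ccc(Cl)cc4)cs3)NC2=O)cc1` differs from compound 3 by methoxy in place of methyl on an aromatic carbon, the same change as between compound 1 and compound 2. A modest lowering, a 2.5-fold lower number from compound 3 to compound 4 (0.40 log units; beyond the scatter), is expected, kept smaller than the earlier step because the step of an at least 4.2-fold lower number from compound 1 to compound 2 (0.63 log units; beyond the scatter) rests on a limit. Compound 4 is therefore expected to give about 200 nM, between 70 nM and 700 nM.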

Compound 4, half-maximal inhibitory concentration: 400 nM
The estimate for compound 4 lay 2.0-fold (0.30 log units) below the measured number; low and high end bracket the measured number.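

In this assay the change from 4-methylphenyl to 4-methoxyphenyl gives a 1.3-fold lower number from compound 3 to compound 4 (0.10 log units; within the scatter), so on this core it has no effect that can be told from the scatter. The size of the step therefore does not carry over from the core of compound 1 to the core of compound 3: the same change on two cores in this assay, an at least 4.2-fold lower number (0.63 log units; beyond the scatter) from compound 1 to compound 2 and a 1.3-fold lower number (0.10 log units; within the scatter) from compound 3 to compound 4, at least 3.4-fold (0.53 log units) apart, beyond the scatter of two such steps. The earlier step has a limit at one end, so its true size stays unknown, and two cores alone do not show why the steps differ: the limit of > 50000 nM in this assay, at which 1 of the 4 values shown sits.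

The compounds shown leave open whether a hydroxyl or an amine in place of the methoxy would also separate the two cores. They also leave open whether an ethoxy group would do so.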